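The source may hold more compounds than are shown below. What is called first, only, known or untested is meant among the compounds shown, and "the series" means these compounds.

Three compounds share one core and differ only in the group on the aromatic ring. Compound 1 `CC1(C)C[C@H](O)C[C@](C)(CNc2cccc(C(F)(F)F)c2)C1` carries a trifluoromethyl group, and in an ADME assay on MDCK cells (Canis lupus familiaris) for cytotoxicity, read by MTT assay, with a stated time of 3 days (on this read-out higher numbers stand for lower toxicity in this test and lower numbers for higher toxicity in this test), compound 1 gives 7800 nM. Compound 2 `CC1(C)C[C@H](O)C[C@](C)(CNc2cccc(C(N)=O)c2)C1` carries a carbamoyl group instead. In this assay compound 2 gives > 100000 nM, which is a limit of the assay rather than a number. Compound 3 `CC1(C)C[C@H](O)C[C@](C)(CNc2cccc(S(N)(=O)=O)c2)C1` carries a sulfamoyl group. In this assay compound 3 gives > 100000 nM, again a limit and not a number. The two exchanges from the trifluoromethyl compound were both large: an at least 12-fold higher number from compound 1 to compound 2 (1.10 log units; beyond the scatter) and an at least 12-fold higher number from compound 1 to compound 3 (1.10 log units; beyond the scatter). Between the two limits the step is unreadable: a step that the two limits leave unreadable from compound 2 to compound 3. Compound 3 therefore stands only at the limit of > 100000 nM in this assay, at which 2 of the 3 values shown sit, with no exact number known.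

Compound 4 `COc1ccc(NC[C@@]2(C)C[C@@H](O)CC(C)(C)C2)cc1S(N)(=O)=O` keeps the sulfamoyl group and adds one more change: methoxy in place of hydrogen on an aromatic carbon. For the measured compounds named here, no measured step concerns a methoxy group, so the bearing evidence is only that compound 3 sits at the limit. The expected step of a number no higher from compound 3 to compound 4 (the limit leaves the size open) is none beyond the scatter. Compound 4 is expected to give 100000 nM, within a range from 30000 nM to 300000 nM.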

Compound 4, half-maximal cytotoxic concentration: > 100000 nM
Compound 4: a limit, no number; the forecaster's own chance of this, stated with the estimate: 60%; the middle value sits exactly at the limit.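

No new step can be read between compound 3 and compound 4, as both give only a limit and not a number: the limit of > 100000 nM in this assay, at which 3 of the 4 values shown sit. The compounds shown leave open whether methoxy in place of hydrogen changes this read-out at all, and how far past that limit compound 2, compound 3 and compound 4 lie.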